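This account rests on a few compounds, and the source may have more. Where it says the series, first, only, none or still open, it means among the compounds named here.

Compound 1 `O=C1C=C[C@@H](OCc2ccccc2)[C@@H]([C@@H](COC(=O)/C=C/c2ccc(F)cc2)OCc2ccccc2)O1` and compound 2 `O=C1C=C[C@@H](OCc2ccccc2)[C@@H]([C@@H](COC(=O)/C=C/c2ccc([N+](=O)[O-])cc2)OCc2ccccc2)O1` share one core and differ at a single point: nitro in place of fluoro on an aromatic carbon. In a functional assay on MDA-MB-231 cells (Homo sapiens) for antiproliferative activity, read by MTT assay, with a stated time of 6 days (a lower number here means a stronger inhibitor, a higher number a weaker inhibitor), compound 1 gives 3580 nM, while compound 2 gives 1550 nM, a step recorded as a 2.3-fold lower number from compound 1 to compound 2 (0.36 log units; beyond the scatter). Compound 3 `CC(=O)O[C@@H]1C=CC(=O)O[C@@H]1[C@@H](COC(=O)/C=C/c1ccc(F)cc1)OC(C)=O` rests on a second core, and the difference between the two cores is not broken down here. In this assay compound 3 gives 34400 nM, the highest of the three numbers. Compound 4 `CC(=O)O[C@@H]1C=CC(=O)O[C@@H]1[C@@H](COC(=O)/C=C/c1ccc([N+](=O)[O-])cc1)OC(C)=O` stands to compound 3 as compound 2 stands to compound 1, with nitro in place of fluoro on an aromatic carbon at the same place, so the change is the same. For compound 4 a step of a 2.3-fold lower number from compound 3 to compound 4 (0.36 log units; beyond the scatter) is expected, because the identical change once produced a 2.3-fold lower number from compound 1 to compound 2 (0.36 log units; beyond the scatter). Compound 4 is therefore estimated at 15000 nM in this assay, expected to fall between 7000 nM and 32000 nM.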

Compound 4, half-maximal inhibitory concentration: 6930 nM
The estimate for compound 4 lay 2.2-fold (0.34 log units) above the measured number; the measured number lies below the stated range.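

In this assay, nitro in place of fluoro on the aromatic carbon gives a 5.0-fold lower number from compound 3 to compound 4 (0.70 log units; beyond the scatter), so the change lowers the number on the second core as it did on the first. The two steps agree in direction, and their sizes cannot be told apart: the same change on two cores in this assay, a 2.3-fold lower number (0.36 log units; beyond the scatter) from compound 1 to compound 2 and a 5.0-fold lower number (0.70 log units; beyond the scatter) from compound 3 to compound 4, 2.1-fold (0.33 log units) apart, within the scatter of two such steps. Within the data shown here, this rests on only two pairs, both 4-fluorophenyl to 4-nitrophenyl, and it shows neither why the step arises nor that it would hold on a further core.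

The compounds shown leave open whether an amine or a carboxylic acid at the same place would follow either core in the same way. They also leave open which part of the difference between the two cores accounts for the gap in their numbers.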